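The source may hold more compounds than are shown below. What is called first, only, known or untested is meant among the compounds shown, and "the series" means these compounds.

Compound 1 `OC1CC(NCc2ccccc2)CCc2sccc21` and compound 2 `Nc1ccc2c(c1)CCC(NCc1ccccc1)CC2` have both been measured in an assay on membranes from liver for displacement of a labelled ligand from Sigma intracellular receptor 2 (Rattus norvegicus), read by scintillation counting, with a stated time of 120 min; a higher number here means a weaker inhibitor, a lower number a stronger inhibitor. There compound 1 gives 606 nM, and compound 2 gives 770 nM; compound 1 has the lower of the two numbers, but its gap to compound 2 lies within the scatter, so the two cannot be told apart. Going by the values given here, no step between two measured compounds that differ in a single place is available here. Compound 3 `c1ccc(CNC2CCc3ccsc3CC2)cc1` differs from compound 1 in one place: hydrogen in place of hydroxy on a saturated ring carbon, in words, hydrogen in place of hydroxy on a saturated ring carbon. Among the compounds with values here, the measured pair gives no precedent for removing this group from the core of compound 1. The expected step is a 1.5-fold lower number from compound 1 to compound 3 (0.18 log units; within the scatter), toward a stronger inhibitor if anything, not clearly beyond the scatter. Compound 3 is therefore expected to give 400 nM in this assay, within a range of 120 nM to 1300 nM.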

Compound 3, inhibition constant: 50 nM
Estimate against measurement, compound 3: 8.0-fold (0.90 log units) above, outside the stated range (below it).
By their numbers in this assay, from the lowest: compound 3; then compounds 1 and 2 (each within the scatter of the next).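

In this assay, hydrogen in place of hydroxy on this saturated ring carbon gives a 12-fold lower number from compound 1 to compound 3 (1.08 log units; beyond the scatter), a large step beyond the scatter. This shows that the position, two ring bonds from the ring atom that bears the group of 8 heavy atoms, is not indifferent to what it carries, something that compound 1 and compound 2 alone could not reveal, since their values lie within the scatter of each other. Nothing shown here accounts for the size of this step.

On these data alone, how a methoxy group, a fluorine atom or an amine on this same ring carbon would compare with hydroxy and hydrogen remains open. Also open, as far as these compounds go, is whether this change would give a step of similar size on any core other than that of compound 1.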